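Swapping the aryl group on the aromatic nitrogen

This account rests on a few compounds, and the source may have more. Where it says the series, first, only, none or still open, it means among the compounds named here.

Compound 1 `Oc1cc(C(F)(F)F)ccc1-c1nc(-c2ccccc2O)n(-c2ccc(F)cc2)n1`: 86.7%
Compound 2 `Oc1cc(C(F)(F)F)ccc1-c1nc(-c2ccccc2O)n(-c2ccc(OC(F)(F)F)cc2)n1`: 84.9%

In a functional assay on PC-12 cells (Rattus norvegicus) for cytotoxicity, read by MTT assay, with stated times of 2 h and 24 h, tested at 5 uM (a higher number here means a stronger effect of the compound at the concentration tested, a lower number a weaker effect), compound 2 gives 84.9%, the lower of the two numbers; compound 1 gives 86.7%, and the two lie within the scatter. Compound 3 `Oc1cc(C(F)(F)F)ccc1-c1nc(-c2ccccc2O)n(-c2ccccc2C(F)(F)F)n1` differs from compound 2 by 2-(trifluoromethyl)phenyl in place of 4-(trifluoromethoxy)phenyl on an aromatic nitrogen. For the measured compounds named here, the one measured step, a number 1.8 percentage points lower from compound 1 to compound 2 (within the scatter), also exchanged the group on the aromatic nitrogen and stayed within the scatter. Going by the values given here, no measured step covers a 2-(trifluoromethyl)phenyl group there, so compound 3 is expected to show no step beyond the scatter, a number 0.9 percentage points lower from compound 2 to compound 3 (within the scatter). Compound 3 is therefore estimated at 84%, between 70% and 95%.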

Compound 3, a percentage reported as activity, at one concentration (the size of the read-out at that concentration, not a potency): 80%
For compound 3 the middle estimate is 4 percentage points above the measured one; the measured number falls inside the stated range.
By their numbers in this assay, from the lowest: compounds 3, 2 and 1 (each within the scatter of the next).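

With 2-(trifluoromethyl)phenyl on the aromatic nitrogen, this assay shows a number 4.9 percentage points lower from compound 2 to compound 3 (within the scatter) and a number 6.7 percentage points lower from compound 1 to compound 3 (within the scatter). A third aryl group, and the first whose name places its substituent at the 2-position rather than the 4-position, therefore still gives no step beyond the scatter at this nitrogen. No measurement bearing on this result is available. The compounds shown leave open whether an aryl group bearing an amine or a carboxylic acid, or a plain alkyl chain in place of the aryl group, would give a step beyond the scatter.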